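From 2-cyanobenzyl to 4-chlorobenzyl on the shared core

The compounds below may be only part of what the source reports. "The series", "measured", "known", "first", "only" and "open" are said of these compounds alone.

In a functional assay on HepG2 cells (Homo sapiens) for antiproliferative activity, read by MTT assay, with a stated time of 24 h (on this read-out lower numbers stand for stronger inhibition and higher numbers for weaker inhibition), compound 3 `COc1cc(OC)c(-c2coc3cc(OCc4ccccc4C#N)ccc3c2=O)cc1OC` gives > 10000 nM, which is a limit and not a number. Compound 1 `COc1cccc(C(=O)Oc2ccc3c(=O)c(-c4cc(OC)c(OC)cc4OC)coc3c2)c1` gives > 10000 nM, also a limit. Compound 2 `COc1cc(OC)c(-c2coc3cc(OCc4ccc(F)cc4)ccc3c2=O)cc1OC` gives a true number, 1000 nM.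

Compound 4 `COc1cc(OC)c(-c2coc3cc(OCc4ccc(Cl)cc4)ccc3c2=O)cc1OC` follows from compound 3 by 4-chlorophenyl in place of 2-cyanophenyl on a saturated chain carbon bound to an oxygen on an aromatic ring.

The step closest to this one is an at least 10-fold higher number from compound 2 to compound 3 (1.00 log units; beyond the scatter), where 2-cyanophenyl enters in place of 4-fluorophenyl. The step at hand removes 2-cyanophenyl, so that change is read in reverse, and a lower number is expected. an at least 10-fold lower number from compound 1 to compound 2 (1.00 log units; beyond the scatter) bears on it only indirectly, and a step that the two limits leave unreadable from compound 1 to compound 3 gives no size. Compound 3 offers only a limit as a starting point, so the size stays uncertain. The expected change is an at least 6.6-fold lower number from compound 3 to compound 4 (0.82 log units; beyond the scatter). For compound 4 the estimate is 1500 nM, with an expected range of 500 nM to 8000 nM.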

Compound 4, half-maximal inhibitory concentration: 940 nM
For compound 4 the middle estimate is 1.6-fold (0.20 log units) above the measured one; measured number inside the range.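

In this assay, chloro in place of fluoro on an aromatic carbon leaves the read-out unchanged: a 1.1-fold lower number from compound 2 to compound 4 (0.03 log units; within the scatter). With 4-fluorobenzyl and 4-chlorobenzyl now both on the shared core, the gap to 2-cyanobenzyl holds for a second compound, an at least 10-fold lower number from compound 3 to compound 4 (1.02 log units; beyond the scatter), and the gap to (3-methoxyphenyl)carbonyl does too, an at least 10-fold lower number from compound 1 to compound 4 (1.02 log units; beyond the scatter). Both of these larger steps start from a limit, so their sizes are lower bounds only: the limit of > 10000 nM in this assay, at which 2 of the 4 values shown sit.

The step from 2-cyanophenyl to 4-chlorophenyl changes the group and its place on the ring together, and the compounds shown do not separate the two; 2-chlorobenzyl and 4-cyanobenzyl would. On these data alone, whether plain benzyl or 4-aminobenzyl on the same oxygen keeps the read-out of compound 2 and compound 4 also stays open.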